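The compounds below may be only part of what the source reports. "The series", "measured", "known", "first", "only" and "open" are said of these compounds alone.

Measured in a functional assay on PC-3 cells (Homo sapiens); a higher number here means a weaker inhibitor of growth, a lower number a stronger inhibitor of growth:
Compound 1 `O=S(=O)(/C=C/c1ccc(F)cc1)Cc1ccc(Nc2ncnc3ccccc23)cc1`: 1000 nM
Compound 2 `O=S(=O)(/C=C/c1ccc(Cl)cc1)Cc1ccc(Nc2ncnc3ccccc23)cc1`: 43000 nM

For the measured compounds named here, of the two, compound 2 has the higher number, 43000 nM, which makes it the weaker inhibitor of growth, and compound 1 is its only neighbour. Compound 3 `O=S(=O)(/C=C/c1ccc(C(F)(F)F)cc1F)Cc1ccc(Nc2ncnc3ccccc23)cc1` has not yet been measured in this assay. It differs from compound 2 as follows: 2-fluoro-4-(trifluoromethyl)phenyl in place of 4-chlorophenyl on a double-bonded chain carbon bound to a double-bonded chain carbon. Thus 2-fluoro-4-(trifluoromethyl)phenyl stands in place of 4-chlorophenyl on a double-bonded chain carbon bound to a double-bonded chain carbon.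

Going by the values given here, only one measured step bears on this change: a 43-fold higher number from compound 1 to compound 2 (1.63 log units; beyond the scatter), a large one, with chloro in place of fluoro on an aromatic carbon. Compound 3 has no chloro and carries fluoro again, so a move towards a lower number is expected, the reverse direction of that step. Among the compounds with values here, no measured compound carries the entering group, however, so only part of that size is expected. The expected change is a 7.2-fold lower number from compound 2 to compound 3 (0.86 log units; beyond the scatter). For compound 3 the estimated value is 6000 nM, with an expected range from 800 nM to 40000 nM.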

Compound 3, concentration for 50% growth inhibition: 100000 nM
Estimate against measurement, compound 3: 17-fold (1.22 log units) below, and the stated range ends below it.
By their numbers in this assay, from the lowest: compound 1; then compound 2; then compound 3.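

In this assay, the aryl group on the double-bonded chain carbon does not follow a simple rule in which a fluoro substituent brings the number down: replacing 4-chlorophenyl with 2-fluoro-4-(trifluoromethyl)phenyl gives a 2.3-fold higher number from compound 2 to compound 3 (0.37 log units; beyond the scatter) in place of the fall that the fluoro group alone might have suggested. Measured against the 4-fluorophenyl group, the same entering group gives a 100-fold higher number from compound 1 to compound 3 (2.00 log units; beyond the scatter), so fluoro on the ring does not by itself restore the low number of compound 1, and among these three groups only 4-fluorophenyl gives a number far under the other two. Nothing measured here accounts for this order.

Going by these compounds, the fluoro and trifluoromethyl parts enter together in compound 3, so their separate shares in the rise remain open, and a phenyl ring carrying only one of them would be needed to tell them apart. On these data alone, it is also open where an unsubstituted phenyl, a methoxy-bearing phenyl or an amine-bearing phenyl would fall relative to compound 1.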